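Swapping fluoro for methoxy on the phenyl of compound 3

The source may hold more compounds than are shown below. What is called first, only, known or untested is meant among the compounds shown, and "the series" means these compounds.

Compound 1, `CC(C)CCn1ccc(CCc2ccccc2)c(C#N)c1=O`, in a functional assay on CHO cells for positive allosteric modulation of metabotropic glutamate receptor 2 (Homo sapiens), with a stated time of 30 min (a higher number here means that more compound is needed for the effect, a lower number that less compound is needed), gives 361 nM.
Compound 2, `CC(C)CCn1ccc(OCc2ccccc2)c(C#N)c1=O`, in this assay gives 2950 nM.
Compound 3, `N#Cc1c(N2CCC(c3ccccc3F)CC2)ccn(CC2CC2)c1=O`, in this assay gives 81 nM.

Compound 3 has the lowest number of the three measured compounds, so the least compound is needed for its effect. Compound 1 is nearest to it, with a number higher by an amount beyond the usual scatter, and compound 2 is furthest, well beyond the scatter. Compound 3 is also the only one of the three that carries a piperidine bearing a fluorophenyl group, and the step to compound 4 keeps everything else and changes just that group.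

Compound 4, `COc1ccccc1C1CCN(c2ccn(CC3CC3)c(=O)c2C#N)CC1`, differs from compound 3 in one place: methoxy in place of fluoro on an aromatic carbon. For the measured compounds named here, no measured pair here shows such an exchange, so its effect is unknown. A small step is expected, within the scatter or slightly toward a higher number, because compound 3 gives 81 nM and a single small change on a ring at the edge of the molecule rarely moves things far. Compound 4 is therefore estimated at 120 nM, within 40 nM to 400 nM, a step of a 1.5-fold higher number from compound 3 to compound 4 (0.17 log units; within the scatter).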

Compound 4, half-maximal effective concentration: 35 nM
Beside the measured number, compound 4's estimate is 3.4-fold (0.54 log units) above it; the measured number lies below the stated range.
By their numbers in this assay, from the lowest: compound 4; then compound 3; then compound 1; then compound 2.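

In this assay, going from 2-fluorophenyl to 2-methoxyphenyl gives a 2.3-fold lower number from compound 3 to compound 4 (0.36 log units; beyond the scatter), so the group on this aromatic carbon, ortho to a large group, does matter. The position also accepts more atoms: methoxy has 2 heavy atoms and 1 hydrogen-bond acceptor where fluoro has 1 heavy atom and 0 hydrogen-bond acceptors, yet less compound is needed, not more. Nothing available here tells which of these differences, if either, lies behind the shift.

The compounds shown hold only fluoro and methoxy at this position, so it stays open how a longer chain such as ethoxy, a hydroxy group, an amine or a carboxylic acid would behave there. Also open, going by these compounds, is whether the same exchange would give a similar step with a different group elsewhere on the shared core.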